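The source may report more compounds than this note shows. Statements on the series, on what has been measured and on what is new or still open speak of the compounds shown alone.

Measured compounds:
compound 1 `Cc1nc(-c2cccnc2)sc1-c1nnc(Cc2ccccc2)o1` — > 100 ug/mL
compound 2 `COc1ccccc1-c1nnc(-c2sc(-c3cccnc3)nc2C)o1` — > 100 ug/mL
compound 3 `Cc1nc(-c2cccnc2)sc1-c1nnc(-c2ccccc2)o1` — > 100 ug/mL

In an ADME assay on PANC-1 cells (Homo sapiens) for cytotoxicity, read by MTT assay (on this read-out lower numbers stand for higher toxicity in this test and higher numbers for lower toxicity in this test), compound 3 gives > 100 ug/mL, which is a limit of the assay and not a number. Compound 1 likewise reaches only a limit, > 100 ug/mL. Compound 2 also stands at a limit, > 100 ug/mL. All three values sit at the limit of > 100 ug/mL in this assay, at which 3 of the 3 values shown sit, so compound 3 can be placed only at that limit, not above or below either neighbour.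

The next compound, compound 4 `Cc1ccccc1-c1nnc(-c2sc(-c3cccnc3)nc2C)o1`, differs from compound 3 by methyl in place of hydrogen on an aromatic carbon. The measured steps that end at compound 3 are the change from compound 1 to compound 3, a step that the two limits leave unreadable from compound 1 to compound 3, and the change from compound 2 to compound 3, a step that the two limits leave unreadable from compound 2 to compound 3; the step from compound 1 to compound 2, a step that the two limits leave unreadable from compound 1 to compound 2, is of the same kind. None of them gives a readable size, since every value involved is a limit. For the measured compounds named here, no measured step therefore bears on the methyl in place of hydrogen in a readable way, and the only expectation that the numbers support is that compound 4 again sits at the limit, with a step that the limit leaves unreadable from compound 3 to compound 4 expected to stay within scatter. Compound 4 is estimated at 150 ug/mL, with a range from 80 ug/mL to 300 ug/mL.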

Compound 4, half-maximal cytotoxic concentration: > 100 ug/mL
Compound 4 gave a limit, no number; the forecaster's own chance of this, stated with the estimate: 85%; the middle value lies beyond the limit too.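

No step can be read among compound 1, compound 2, compound 3 and compound 4 in this assay, since all four rest at one limit and give no number: the limit of > 100 ug/mL in this assay, at which 4 of the 4 values shown sit. The compounds shown leave open whether methyl, methoxy, hydrogen or the change from benzyl alters the half-maximal cytotoxic concentration at all, and in which direction.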